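A few compounds are considered here, and "the series" means these few. Any claim that something is new, unique, unknown or untested is made for them only; others in the source may bear on it.

In a physicochemical assay for lipophilicity, read by HPLC, measured as chromatographic lipophilicity, at pH 7.4 (on this read-out higher numbers stand for higher lipophilicity and lower numbers for lower lipophilicity), three compounds have been measured:
Compound 1 `COc1cccc(NC(=O)c2nnn(Cc3ccc(-n4cccn4)cc3)c2N)c1` gives 2.4.
Compound 2 `COc1cccc(NC(=O)c2nnn(Cc3ccc(OC(F)(F)F)cc3)c2N)c1` gives 3.6.
Compound 3 `COc1cccc(NC(=O)c2nnn(Cc3ccc(C#N)cc3)c2N)c1` gives 2.3.

On these numbers compound 1 sits close to compound 3, within the scatter, and well below compound 2. Compound 4 `COc1cccc(NC(=O)c2nnn(Cc3ccc(C4CC4)cc3)c2N)c1` differs from compound 1 in one place: cyclopropyl in place of 1H-pyrazol-1-yl on an aromatic carbon. Going by the values given here, two measured steps bear on this, both also replacing the 1H-pyrazol-1-yl group: a number 1.20 log units higher from compound 1 to compound 2 (beyond the scatter) and a number 0.10 log units lower from compound 1 to compound 3 (within the scatter). Exchanging this group can therefore leave this assay flat or raise it a great deal, depending on what enters. For compound 4 a clear rise is expected, a number 0.90 log units higher from compound 1 to compound 4 (beyond the scatter). Compound 4 is estimated at 3.3, within a range from 2.8 to 3.8.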

Compound 4, distribution coefficient: 3.2
Compound 4: the middle estimate sits 0.10 log units above what was measured; the measured number falls inside the stated range.
By their numbers in this assay, from the lowest: compounds 3 and 1 (each within the scatter of the next); then compound 4; then compound 2.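

In this assay, cyclopropyl on this aromatic carbon gives a number 0.80 log units higher from compound 1 to compound 4 (beyond the scatter), a number 0.90 log units higher from compound 3 to compound 4 (beyond the scatter) and a number 0.40 log units lower from compound 2 to compound 4 (beyond the scatter). Going by these compounds alone, compound 4 therefore sits on a level of its own, so this position, para to a large group, shows more than the low pair and the single high value seen earlier. Nothing shown here accounts for these differences. Where a carboxylic acid, an amine or a longer carbon chain at this position would fall on this scale remains open.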